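Methoxymethyl in place of trifluoromethyl on a weak series

The source may report more compounds than this note shows. Statements on the series, on what has been measured and on what is new or still open speak of the compounds shown alone.

Compound 1, `CC1=C(C(=O)NCCCN2CCC(c3ccccn3)CC2)[C@@H](c2ccc(F)c(F)c2)NC(=O)N1`, gives > 2000 nM in an assay on LM cells with Alpha-1B adrenergic receptor (Homo sapiens) as the target; on this read-out higher numbers stand for weaker inhibition and lower numbers for stronger inhibition. Compound 2, `O=C1NC(C(F)(F)F)=C(C(=O)NCCCN2CCC(c3ccccn3)CC2)[C@@H](c2ccc(F)c(F)c2)N1`, gives > 2000 nM in this assay.

Both of these values are limits of the assay, not numbers. For the measured compounds named here, compound 2 therefore stands at the limit of > 2000 nM in this assay, at which 2 of the 2 values shown sit, and so does the only other measured compound. Going by the values given here, the one step that joins them, a step that the two limits leave unreadable from compound 1 to compound 2, cannot be sized for that reason.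

Compound 3, `COCC1=C(C(=O)NCCCN2CCC(c3ccccn3)CC2)[C@@H](c2ccc(F)c(F)c2)NC(=O)N1`, is the next member. Its difference from compound 2 is methoxymethyl in place of trifluoromethyl on a double-bonded ring carbon. Among the compounds with values here, no measured step reads as a number, so nothing in this set points in either direction for this change, and the prior step from compound 1 to compound 2 gave no readable size.

Compound 3 is therefore expected to stay near the limit, with the step that the limit leaves unreadable from compound 2 to compound 3 estimated as small. The estimate for compound 3 is 4000 nM, within 1000 nM to 20000 nM.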

Compound 3, inhibition constant: 235 nM
For compound 3 the middle estimate is 17-fold (1.23 log units) above the measured one; measured number outside the range, below it.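

For the compounds shown here, this ring carbon is not indifferent to what it carries: methoxymethyl brings the first readable number of the set in this assay, with an at least 8.5-fold lower number from compound 2 to compound 3 (0.92 log units; beyond the scatter) in place of trifluoromethyl. Methoxy in place of hydrogen on a saturated chain carbon bound to a double-bonded ring carbon likewise gives an at least 8.5-fold lower number from compound 1 to compound 3 (0.92 log units; beyond the scatter), so one added oxygen-bearing group separates a measurable compound from one at the limit. The step between the two limits cannot be read, and these two steps give only minimum sizes, since their starting values are limits of the assay, not numbers: the limit of > 2000 nM in this assay, at which 2 of the 3 values shown sit.

Going by these compounds, whether the oxygen itself matters stays open, and a propyl group, with carbon where methoxymethyl has its oxygen, would separate oxygen from chain length. On these data alone, how far the trend runs is also open, as with a longer ether such as ethoxymethyl or with hydroxymethyl.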